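Carbamate series: aryl swap on the amide nitrogen

A few compounds are considered here, and "the series" means these few. Any claim that something is new, unique, unknown or untested is made for them only; others in the source may bear on it.

Measured so far in a functional assay on PANC-1 cells (Homo sapiens) for inhibition, read by MTT assay, with a stated time of 24 h, tested at 10 uM; on this read-out lower numbers stand for less inhibition and higher numbers for more inhibition at the one concentration tested (going by the name of the read-out):
compound 1 `CC(C)=CCC1Cc2c(OCCCNC(=O)c3cccs3)cc(=O)n(CCCO)c2CC1(C)C` — 33.6%
compound 2 `CC(C)=CCC1Cc2c(OC(=O)Nc3ccccc3F)cc(=O)n(CCCO)c2CC1(C)C` — 52.3%

Within the data shown here, compound 2 stands highest of the two numbers; the only step measured, a number 18.7 percentage points higher from compound 1 to compound 2 (beyond the scatter), separates it from compound 1 and lies beyond the scatter.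

Compound 3 `CC(C)=CCC1Cc2c(OC(=O)Nc3ccc(Cl)cc3)cc(=O)n(CCCO)c2CC1(C)C` differs from compound 2 in one place: 4-chlorophenyl in place of 2-fluorophenyl on an amide-type nitrogen. Among the measured compounds shown here, the one measured step replaced the whole side group on the ring oxygen with a carbamate and so says nothing about a change of the aryl ring within that carbamate. For the measured compounds named here, no measured step therefore bears on this change, and the direction is not indicated by the data.

With the carbamate kept, compound 3 is expected to stay near compound 2, a step of a number 0.3 percentage points lower from compound 2 to compound 3 (within the scatter), within the scatter. The estimate for compound 3 in this assay is 52%, with a range from 36% to 68%.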

Compound 3, a percentage reported as inhibition, at one concentration (the size of the read-out at that concentration, not a potency): 49.8%
Compound 3: middle estimate off by 2.2 percentage points, on the high side; measured number inside the range.
By their numbers in this assay, from the lowest: compound 1; then compounds 3 and 2 (each within the scatter of the next).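

In this assay, the aryl ring on the amide-type nitrogen of the carbamate can now be judged directly: with a number 2.5 percentage points lower from compound 2 to compound 3 (within the scatter) the swap of 2-fluorophenyl for 4-chlorophenyl gives no readable change at this position. The gain over the side group of compound 1 also no longer rests on a single carbamate, as a number 16.2 percentage points higher from compound 1 to compound 3 (beyond the scatter) stands alongside the earlier step and holds with a second aryl ring. No measured evidence bears on the reason for either step.

Still open, as far as these compounds go, is whether the number holds when the aryl ring on this nitrogen gives way to a non-aromatic ring such as cyclohexyl or to a benzyl group. Also open, from the compounds shown here alone, is how a carboxylic acid or a dimethylamino group on that ring would read.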